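Replacing 3-aminophenyl with 4-(trifluoromethyl)phenyl

The compounds below may be only part of what the source reports. "The series", "measured", "known", "first", "only" and "open" are said of these compounds alone.

In a functional assay on HCT-116 cells (Homo sapiens) for cytotoxicity, read by MTT assay, with a stated time of 72 h (on this read-out lower numbers stand for stronger inhibition and higher numbers for weaker inhibition), compound 1 `COc1cc(Nc2nc3ccccc3nc2S(=O)(=O)c2ccc(C)cc2)cc(OC)c1` gives > 50000 nM as its reading, which is a limit and not a number. Within the data shown here, compound 2 `Cc1ccc(S(=O)(=O)c2nc3ccccc3nc2Nc2cccc(N)c2)cc1` gives 2390 nM as the only true number so far. Compound 3 `Cc1ccc(S(=O)(=O)c2nc3ccccc3nc2Nc2ccc(C(F)(F)F)cc2)cc1` carries 4-(trifluoromethyl)phenyl in place of 3-aminophenyl on a nitrogen on an aromatic ring. Among the measured compounds shown here, the one measured step that bears on this change is an at least 20-fold lower number from compound 1 to compound 2 (1.32 log units; beyond the scatter) and it came with 3-aminophenyl in place of 3,5-dimethoxyphenyl at that kind of nitrogen, so losing 3-aminophenyl is expected to give a higher number, meaning weaker inhibition, by a moderate to large step in this assay on this single piece of evidence. The estimated change is a 5.0-fold higher number from compound 2 to compound 3 (0.70 log units; beyond the scatter) and it remains uncertain. Compound 3 is expected at 12000 nM within an estimated range from 2500 nM to 50000 nM in this assay.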

Compound 3, half-maximal inhibitory concentration: 950 nM
Estimate against measurement, compound 3: 13-fold (1.10 log units) above; the whole stated range lies above it.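

In this assay, the change to 4-(trifluoromethyl)phenyl gives a 2.5-fold lower number from compound 2 to compound 3 (0.40 log units; beyond the scatter), so activity at this nitrogen does not depend on 3-aminophenyl, even though the entering group lacks the hydrogen-bond donor and acceptor counted for the group that leaves. Against 3,5-dimethoxyphenyl, the same group gives an at least 52-fold lower number from compound 1 to compound 3 (1.72 log units; beyond the scatter), which means two quite different groups both give lower numbers than 3,5-dimethoxyphenyl. Compound 1 stands at a limit, so this step has no exact size: the limit of > 50000 nM in this assay, at which 1 of the 3 values shown sits.

The two active groups differ both in their substituent and in where it sits on the phenyl ring, so the compounds shown cannot separate these two features. On these data alone, what a plain phenyl group or a phenyl bearing a carboxylic acid would give at this nitrogen remains open.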